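Amide to Carbamate on a Pyrazole Amine

The compounds below may be only part of what the source reports. "The series", "measured", "known", "first", "only" and "open" are said of these compounds alone.

Of the compounds shown here, two have been tested in an assay on CHO-K1 cells for displacement of a labelled ligand from prostaglandin E2 receptor EP1 subtype (Homo sapiens); a higher number here means a weaker inhibitor, a lower number a stronger inhibitor. Compound 1, `Cc1cc(C(=O)NN2CCCCC2)nn1Cc1cc(Cl)ccc1OCC(C)C`, gives 200 nM in this assay. Compound 2, `Cc1cc(NC(=O)C(C)C)nn1Cc1cc(Cl)ccc1OCc1ccccc1`, gives 25.1 nM in this assay. Compound 2 therefore has the lower of the two numbers, and the gap to compound 1 lies beyond the usual scatter, so compound 2 is the stronger inhibitor of the pair. The two compounds differ in more than one place, so nothing can be drawn from their gap about any single group.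

Compound 3, `Cc1cc(NC(=O)O[C@H]2CCOC2)nn1Cc1cc(Cl)ccc1OCc1ccccc1`, has not yet been measured. It is built from compound 2 by one change: (oxolan-3-yl)oxy in place of isopropyl on a carbonyl carbon

No single-point comparison between measured compounds is available to guide this step. Because compound 2 already gives 25.1 nM in this assay, the expectation for compound 3 is a small shift, of about a 1.6-fold higher number from compound 2 to compound 3 (0.20 log units; within the scatter), toward a weaker inhibitor, not clearly beyond the scatter. Compound 3 is thus estimated at 40 nM in this assay, with a plausible range from 10 nM to 160 nM.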

Compound 3, half-maximal inhibitory concentration: 79.4 nM
The estimate for compound 3 lay 2.0-fold (0.30 log units) below the measured number, within the range that was stated.
By their numbers in this assay, from the lowest: compound 2; then compound 3; then compound 1.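

Swapping the isopropyl on the carbonyl carbon for (oxolan-3-yl)oxy turns the amide into a carbamate and gives the first comparison here that changes only one place: a 3.2-fold higher number from compound 2 to compound 3 (0.50 log units; beyond the scatter) in this assay. This shows that the group at this position affects the result, and that this particular change gives a weaker inhibitor. Within the data shown here, the step is modest, though, so the larger group, with its five-membered non-aromatic ring and defined stereocentre, does not abolish inhibition, and nothing measured so far explains why the number rises.

What remains open is which part of the entering group accounts for the step, as the linking oxygen, the ring and the stereocentre all arrive together. A simple isopropoxy group on the same carbonyl carbon would separate the effect of the carbamate oxygen from that of the ring, while the opposite stereoisomer of the oxolan-3-yl group would show whether the defined stereocentre matters.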